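The source may hold more compounds than are shown below. What is called first, only, known or untested is meant among the compounds shown, and "the series" means these compounds.

Measured compounds in a functional assay on NCI-H460 cells (Homo sapiens) for antiproliferative activity, with a stated time of 72 h; on this read-out lower numbers stand for stronger inhibition and higher numbers for weaker inhibition:
compound 1, `C=CC[C@H]1C[C@]2([C@@H](C)Cc3ccc(OC)c(OC)c3)OCOC2=CC1=O`, gives 260 nM
compound 2, `C=CC[C@H]1C[C@]2([C@@H](C)Cc3ccc(OC)c(C)c3)OCOC2=CC1=O`, gives 630 nM
compound 3, `C=CC[C@H]1C[C@]2([C@@H](C)Cc3cc(OC)c(OC)cc3F)OCOC2=CC1=O`, gives 120 nM

Among these three, compound 3 gives the lowest number. Compound 1 stands nearest to it, separated by the step of a 2.2-fold lower number from compound 1 to compound 3 (0.34 log units; beyond the scatter), while compound 2 lies furthest away. Compound 4, `C=CC[C@H]1C[C@]2([C@@H](C)Cc3cc(C)c(OC)cc3F)OCOC2=CC1=O`, differs from compound 3 by methyl in place of methoxy on an aromatic carbon. Within the data shown here, the one measured step that bears on this exchange is a 2.4-fold higher number from compound 1 to compound 2 (0.38 log units; beyond the scatter), the same replacement of methoxy by methyl carried out on the ring lacking the fluoro group. Compound 4 is therefore expected to show a modest rise of about that size in this assay, a 2.4-fold higher number from compound 3 to compound 4 (0.38 log units; beyond the scatter). Compound 4 is accordingly estimated at 290 nM, with a likely range from 150 nM to 600 nM.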

Compound 4, half-maximal inhibitory concentration: 650 nM
Compound 4: middle estimate off by 2.2-fold (0.35 log units), on the low side; measured number above the stated range.
By their numbers in this assay, from the lowest: compound 3; then compound 1; then compounds 2 and 4 (each within the scatter of the next).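

In this assay the exchange of methoxy for methyl with the fluoro group present gives a 5.4-fold higher number from compound 3 to compound 4 (0.73 log units; beyond the scatter) and so raises the number on both cores, with no size difference that can be told apart: the same change on two cores in this assay, a 2.4-fold higher number (0.38 log units; beyond the scatter) from compound 1 to compound 2 and a 5.4-fold higher number (0.73 log units; beyond the scatter) from compound 3 to compound 4, 2.2-fold (0.35 log units) apart, within the scatter of two such steps. With methyl in place, adding the fluoro group gives a 1.0-fold higher number from compound 2 to compound 4 (0.01 log units; within the scatter), and this step too cannot be told apart from its counterpart with methoxy: the same change on two cores in this assay, a 2.2-fold lower number (0.34 log units; beyond the scatter) from compound 1 to compound 3 and a 1.0-fold higher number (0.01 log units; within the scatter) from compound 2 to compound 4, 2.2-fold (0.35 log units) apart, within the scatter of two such steps.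

The compounds shown leave open how a hydroxyl, an ethoxy group or a chloro group would behave at this position.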